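The source may report more compounds than this note shows. Statements on the series, on what has been measured and on what is new or still open speak of the compounds shown alone.

Values in a physicochemical assay for solubility; on this read-out higher numbers stand for higher solubility and lower numbers for lower solubility:
- Compound 1 `O=C1CC[C@@H](C(=O)N2CCC(NS(=O)(=O)c3cc(S(=O)(=O)c4ccccc4)ccc3C(F)(F)F)CC2)N1`: 100000 nM
- Compound 2 `CC(C)C(=O)N1CCC[C@H]1C(=O)N1CCC(NS(=O)(=O)c2cc(S(=O)(=O)c3ccccc3)ccc2C(F)(F)F)CC1`: 100000 nM
- Compound 3 `O=C([C@@H]1CCCN1C(=O)c1ccncc1)N1CCC(NS(=O)(=O)c2cc(S(=O)(=O)c3ccccc3)ccc2C(F)(F)F)CC1`: 100000 nM

Not yet measured: compound 4 `CCNC(=O)N1CCC[C@H]1C(=O)N1CCC(NS(=O)(=O)c2cc(S(=O)(=O)c3ccccc3)ccc2C(F)(F)F)CC1`.

In this assay compound 3 gives 100000 nM, which is level with compound 1 and compound 2 at the digits measured. The next step leads to compound 4, and the change is ethylamino in place of pyridin-4-yl on a carbonyl carbon. In words, ethylamino stands in place of pyridin-4-yl on a carbonyl carbon. Cut one bond further out, the same difference reads (pyridin-4-yl)carbonyl to ethylcarbamoyl.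

Within the data shown here, two measured steps bear on this. The closer one is no change at the digits printed from compound 2 to compound 3 (within the scatter), since it also exchanges a group on a carbonyl carbon and is the step that brought in the pyridin-4-yl now leaving. The other, no change at the digits printed from compound 1 to compound 2 (within the scatter), is a less direct guide. Neither step moved the read-out, so no shift beyond the scatter is expected in this assay, and no direction is favoured. Among the measured compounds shown here, no measured compound carries ethylamino at this place, so the expectation is an extrapolation from three equal values.

The expected outcome is no change at the digits printed from compound 3 to compound 4 (within the scatter). Compound 4 is expected at 100000 nM, with an estimated range of 60000 nM to 130000 nM.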

Compound 4, solubility: 100000 nM
Compound 4: the middle estimate sits on the measured number at the digits printed, and the stated range covers the measured number.
By their numbers in this assay, from the lowest: compounds 1, 2, 3 and 4 (each within the scatter of the next).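

In this assay the exchange of pyridin-4-yl for ethylamino on the carbonyl carbon gives no change at the digits printed from compound 3 to compound 4 (within the scatter) and extends the series at this place to a group with no ring and with a hydrogen-bond donor, where compound 3 has a six-membered aromatic ring and a hydrogen-bond acceptor. Ethylamino in place of isopropyl gives no change at the digits printed from compound 2 to compound 4 (within the scatter) and the wider exchange for the 5-oxopyrrolidin-2-yl group gives no change at the digits printed from compound 1 to compound 4 (within the scatter) so that all four compounds now stand level on this read-out, and neither ring, hydrogen-bond donor nor group size as counted here separates them. No measurement on hand accounts for this flat picture.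

The compounds shown leave open whether any group on this carbonyl carbon can separate itself from these four values, for instance a carboxylic acid, a basic amine such as dimethylamino, or a longer alkyl chain. They also leave open whether the same exchanges would stay level on a changed version of the shared core.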